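The source may report more compounds than this note shows. Statements on the series, on what has been measured and on what is new or still open speak of the compounds shown alone.

Compound 1 `CN(O)/C=C\C(=O)c1ccc(Cl)cc1` and compound 3 `O=C(/C=C\N(O)Cc1ccccc1)c1ccc(Cl)cc1` share one core and differ in a single place. In an assay on RBL-1 cells for inhibition of Polyunsaturated fatty acid 5-lipoxygenase (Rattus norvegicus) (a lower number here means a stronger inhibitor, a higher number a weaker inhibitor), compound 1 gives 550 nM, while compound 3 gives 1500 nM. The change from compound 3 to compound 1 is hydrogen in place of phenyl on a saturated chain carbon bound to an amine nitrogen, and it brings a 2.7-fold lower number from compound 3 to compound 1 (0.44 log units; beyond the scatter). Compound 2 `CC(=O)ON(/C=C\C(=O)c1ccc([N+](=O)[O-])cc1)Cc1ccccc1` rests on a different core; how its core differs from that of compound 3 is not broken down here. In this assay compound 2 reaches only a limit, > 25000 nM. What is known of compound 2 is just (the limit of > 25000 nM in this assay, at which 1 of the 3 values shown sits). Compound 4 `CC(=O)ON(C)/C=C\C(=O)c1ccc([N+](=O)[O-])cc1` has not yet been measured; it differs from compound 2 by hydrogen in place of phenyl on a saturated chain carbon bound to an amine nitrogen, the same change as that from compound 3 to compound 1. The step from compound 2 to compound 4 is expected to be an at least 1.2-fold lower number from compound 2 to compound 4 (0.09 log units; that floor lies within the scatter), resting on a 2.7-fold lower number from compound 3 to compound 1 (0.44 log units; beyond the scatter), though the starting point is only a limit. Compound 4 is therefore estimated at about 20000 nM, between 5000 nM and 80000 nM, with a real chance that only a limit is reported again.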

Compound 4, half-maximal inhibitory concentration: > 25000 nM
Compound 4: no number, only a limit; the forecaster's own chance of this, stated with the estimate: 60%; at least 1.2-fold (0.09 log units) between middle value and limit.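

No step can be read from compound 2 to compound 4, because both stop at the same limit of the assay: the limit of > 25000 nM in this assay, at which 2 of the 4 values shown sit.

The compounds shown leave open what benzyl to methyl does on the core of compound 2.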